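Swapping Methoxy for Propanoylamino: Solubility Expectation

This account rests on a few compounds, and the source may have more. Where it says the series, first, only, none or still open, it means among the compounds named here.

Measured compounds in a physicochemical assay for solubility, read by HPLC, with a stated time of 24 h; on this read-out higher numbers stand for higher solubility and lower numbers for lower solubility:
compound 1 `O=C1O[C@@H](CN2CCCCC2)CN1c1ccc(-n2cc(-c3ccccn3)cn2)c(F)c1` gives 219000 nM
compound 2 `O=C1CSC(=O)N1C[C@H]1CN(c2ccc(-n3cc(-c4ccccn4)cn3)c(F)c2)C(=O)O1` gives 26900 nM
compound 3 `COC[C@H]1CN(c2ccc(-n3cc(-c4ccccn4)cn3)c(F)c2)C(=O)O1` gives 36200 nM

Compound 3 stands second highest of the three numbers, close to compound 2 and well below compound 1. Compound 4 `CCC(=O)NC[C@H]1CN(c2ccc(-n3cc(-c4ccccn4)cn3)c(F)c2)C(=O)O1` carries the change (propanoylamino in place of methoxy on a saturated chain carbon bound to a saturated ring carbon). Within the data shown here, no measured step covers this exact exchange. The two large steps, an 8.1-fold lower number from compound 1 to compound 2 (0.91 log units; beyond the scatter) and a 6.0-fold lower number from compound 1 to compound 3 (0.78 log units; beyond the scatter), both remove piperidin-1-yl, whereas the step of a 1.3-fold higher number from compound 2 to compound 3 (0.13 log units; within the scatter) exchanges one group with no net charge for another and stays within the scatter. The change to compound 4 is again an exchange between groups with no net charge, so the expected step of a 1.1-fold higher number from compound 3 to compound 4 (0.04 log units; within the scatter) is none beyond the scatter. Compound 4 is therefore estimated at 40000 nM, with a range from 15000 nM to 110000 nM.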

Compound 4, solubility: 147000 nM
The estimate for compound 4 lay 3.7-fold (0.57 log units) below the measured number, outside the stated range (above it).
By their numbers in this assay, from the lowest: compounds 2 and 3 (each within the scatter of the next); then compounds 4 and 1 (each within the scatter of the next).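

In this assay propanoylamino in place of methoxy on a saturated chain carbon bound to a saturated ring carbon moves the number beyond the scatter (a 4.1-fold higher number from compound 3 to compound 4 (0.61 log units; beyond the scatter)), so this position does respond to an exchange that leaves no net charge on either group. Propanoylamino also stands clear of 2,4-dioxo-1,3-thiazolidin-3-yl (a 5.5-fold higher number from compound 2 to compound 4 (0.74 log units; beyond the scatter)), yet within the scatter of piperidin-1-yl (a 1.5-fold lower number from compound 1 to compound 4 (0.17 log units; within the scatter)), so among these compounds piperidin-1-yl is not alone in giving a high number. No measurement on hand accounts for this. Open, going by these compounds, is whether the amide hydrogen or the propanoyl chain carries the step, which an N-methyl amide or a longer acyl chain would separate.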